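Methoxy to hydroxy change carried onto compound 3

A few compounds are considered here, and "the series" means these few. Any claim that something is new, unique, unknown or untested is made for them only; others in the source may bear on it.

Compound 1 `CCc1oc2cc(O)ccc2c1C(=O)c1ccc(OC)cc1` and compound 2 `CCc1oc2cc(O)ccc2c1C(=O)c1ccc(O)cc1` share one core and differ only by hydrogen in place of methyl on an oxygen on an aromatic ring. In an assay for inhibition of solute carrier family 22 member 12 (Homo sapiens), read by scintillation counting, with a stated time of 60 min, tested at 50 uM (a lower number here means less inhibition, a higher number more inhibition at the concentration tested (going by the name of the read-out)), compound 1 gives 48.3%, while compound 2 gives 92.1%; the step of a number 43.8 percentage points higher from compound 1 to compound 2 (beyond the scatter). Compound 3 `CCc1cc2c(C(=O)c3cc(Br)c(O)c(Br)c3)c(OC)ccc2o1` carries a different core; the difference between the two cores is not broken down here. In this assay compound 3 gives 99.6%, which lies within the scatter of compound 2 and well beyond that of compound 1. Compound 4 `CCc1cc2c(C(=O)c3cc(Br)c(O)c(Br)c3)c(O)ccc2o1` differs from compound 3 by hydrogen in place of methyl on an oxygen on an aromatic ring, the same change as between compound 1 and compound 2, at the same kind of place. Because compound 3 already sits at 99.6%, a number near the top of the percentage scale, a rise as large as that from compound 1 to compound 2 cannot recur. For compound 4 the expected step is a number 0.6 percentage points lower from compound 3 to compound 4 (within the scatter). Compound 4 is estimated at 99%, with a range from 92% to 100%.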

Compound 4, a percentage reported as inhibition, at one concentration (the size of the read-out at that concentration, not a potency): 99.9%
For compound 4 the middle estimate is 0.9 percentage points below the measured one; measured number inside the range.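

In this assay the methoxy to hydroxy change on the core of compound 3 gives a number 0.3 percentage points higher from compound 3 to compound 4 (within the scatter). The size of the step therefore does not carry over from one core to the other: the same change on two cores in this assay, a number 43.8 percentage points higher (beyond the scatter) from compound 1 to compound 2 and a number 0.3 percentage points higher (within the scatter) from compound 3 to compound 4, 43.5 percentage points apart, beyond the scatter of two such steps. Compound 3 already reads 99.6%, near the top of the percentage scale, and a reading at one concentration at that height does not show whether the change is truly without effect on this core.

The compounds shown leave open how an amine, a carboxylic acid or a longer chain such as ethoxy would read in place of hydroxy or methoxy on the aromatic ring. Which part of the difference between the two cores goes with the high readings also stays open.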